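Ring-Size Change on the Amine of a Weak Adenosine Ligand

A few compounds are considered here, and "the series" means these few. Any claim that something is new, unique, unknown or untested is made for them only; others in the source may bear on it.

Measured compounds:
- compound 1, `CNc1nc(-c2ccccc2)nc2c1nnn2Cc1ccccc1F`: 25000000 nM
- compound 2, `Fc1ccccc1Cn1nnc2c(NC3CC3)nc(-c3ccccc3)nc21`: 15000000 nM
- compound 3, `CNc1nc(-c2ccccc2)nc2c1nnn2Cc1ccccc1`: 353000000 nM

All three were tested in an assay on isolated protein for binding affinity to adenosine receptor A1 (Bos taurus); on this read-out lower numbers stand for stronger inhibition and higher numbers for weaker inhibition. Compound 4, `c1ccc(Cn2nnc3c(NC4CC4)nc(-c4ccccc4)nc32)cc1`, is not yet measured. Compound 1 and compound 2 differ by cyclopropyl in place of methyl on a nitrogen on an aromatic ring, and this change gave a 1.7-fold lower number from compound 1 to compound 2 (0.22 log units; within the scatter). The cores of compound 3 and compound 1 differ by hydrogen in place of fluoro on an aromatic carbon, which gave a 14-fold higher number from compound 1 to compound 3 (1.15 log units; beyond the scatter). Compound 4 relates to compound 3 by the same change, (cyclopropyl in place of methyl on a nitrogen on an aromatic ring), at the same kind of place. Because the earlier step of a 1.7-fold lower number from compound 1 to compound 2 (0.22 log units; within the scatter) stayed within the scatter, the step from compound 3 to compound 4 is expected to be similar in size, namely a 1.7-fold lower number from compound 3 to compound 4 (0.23 log units; within the scatter). Compound 4 is thus estimated to show 210000000 nM in this assay, with a range from 70000000 nM to 600000000 nM.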

Compound 4, inhibition constant: 11000000 nM
For compound 4 the middle estimate is 19-fold (1.28 log units) above the measured one, and the stated range ends above it.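

Carrying the change from methylamino to cyclopropylamino from one core to another did not preserve its size in this assay: on the core of compound 3 it gave a 32-fold lower number from compound 3 to compound 4 (1.51 log units; beyond the scatter), a much larger step than on the fluoro-bearing core: the same change on two cores in this assay, a 1.7-fold lower number (0.22 log units; within the scatter) from compound 1 to compound 2 and a 32-fold lower number (1.51 log units; beyond the scatter) from compound 3 to compound 4, 19-fold (1.28 log units) apart, beyond the scatter of two such steps. The swap of fluoro for hydrogen on an aromatic carbon likewise depends on the amine present, since with cyclopropylamino it gave a 1.4-fold lower number from compound 2 to compound 4 (0.13 log units; within the scatter), unlike its step with methylamino: the same change on two cores in this assay, a 14-fold higher number (1.15 log units; beyond the scatter) from compound 1 to compound 3 and a 1.4-fold lower number (0.13 log units; within the scatter) from compound 2 to compound 4, 19-fold (1.28 log units) apart, beyond the scatter of two such steps. So the two changes do not act independently in these four compounds, but this does not show why, or how the cyclopropylamino change would behave on any other core.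

Going by these compounds, it remains open whether a cyclobutyl group or a longer chain such as propyl on that nitrogen would behave like cyclopropyl. On these data alone, it is equally open whether chloro in place of fluoro would give the same dependence.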